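The compounds below may be only part of what the source reports. "The series", "measured", "known", "first", "only" and "open" are said of these compounds alone.

Measured compounds in this series:

compound 1, `COc1ncnc2c1c(-c1ccsc1)cn2[C@@H]1O[C@H](CO)[C@@H](O)[C@H]1O` — 75300 nM
compound 2, `Cc1ncnc2c1c(-c1cc3ccccc3o1)cn2[C@@H]1O[C@H](CO)[C@@H](O)[C@H]1O` — 84400 nM
compound 3, `C#Cc1cn([C@@H]2O[C@H](CO)[C@@H](O)[C@H]2O)c2nc(C)nc(N)c12` — a limit of the assay, > 100000 nM

In an ADME assay on MRC5 cells (Homo sapiens), read by MTT assay, with a stated time of 72 h (on this read-out lower numbers stand for stronger inhibition and higher numbers for weaker inhibition), compound 2 gives 84400 nM, the highest of the two numbers reported; compound 1 gives 75300 nM, and the gap between compound 1 and compound 2 lies within the scatter of the method, so no order can be read between them. For compound 3 only a limit is reported, > 100000 nM; this is the limit of > 100000 nM in this assay, at which 1 of the 3 values shown sits.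

For the measured compounds named here, no pair of measured compounds differs in a single place, so no measured step is available in this assay to calibrate the change considered here.

Compound 4, `Cc1ncnc2c1c(-c1cccs1)cn2[C@@H]1O[C@H](CO)[C@@H](O)[C@H]1O`, is not yet measured in this assay. It differs from compound 2 by thiophen-2-yl in place of 1-benzofuran-2-yl on an aromatic carbon. Going by the values given here, with every number in this assay sitting near the upper limit and no measured step of this kind to draw on, the expectation for the step from compound 2 to compound 4 is none beyond the scatter, with a real chance that only a limit is returned.

Compound 4 is therefore expected to give about 85000 nM in this assay, within 35000 nM to 200000 nM; this expectation corresponds to a 1.0-fold higher number from compound 2 to compound 4 (0.00 log units; within the scatter).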

Compound 4, half-maximal inhibitory concentration: > 100000 nM
Compound 4 was reported as a limit (the forecaster's own chance of this, stated with the estimate: 35%); middle value at least 1.1-fold (0.07 log units) away from the limit.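

In this assay compound 4 gives > 100000 nM, which is a limit of the assay and not a number. Thiophen-2-yl in place of 1-benzofuran-2-yl gives an at least 1.1-fold higher number from compound 2 to compound 4 (0.07 log units; that floor lies within the scatter): this is the first measured step at this aromatic carbon, and it shows no stronger inhibition with the smaller group, while the true size of the step remains unread. The upper limit of the read-out now bounds a larger share of the series: the limit of > 100000 nM in this assay, at which 2 of the 4 values shown sit.

From the compounds shown here alone, how far the value of compound 4 lies beyond the limit remains open, so the data cannot show whether loss of the six-membered aromatic ring of carbon only changes the number at all. Also open, going by these compounds, is whether an amine or a carboxylic acid on this aromatic carbon, in place of thiophen-2-yl, would give a number clear of the limit and a step beyond the scatter.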